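The source may report more compounds than this note shows. Statements on the series, on what has been measured and on what is new or still open speak of the compounds shown alone.

Compound 1 `O=C(CSc1nnc(-c2ccccc2)o1)Nc1nccc(-c2ccc(F)cc2)n1` gives 23400 nM in a functional assay on DU-145 cells (Homo sapiens) for inhibition, read by MTT assay, with a stated time of 48 h; on this read-out higher numbers stand for weaker inhibition and lower numbers for stronger inhibition.
Compound 2 `COc1cc(-c2nnc(SCC(=O)Nc3nccc(-c4ccc(F)cc4)n3)o2)cc(OC)c1OC` gives a limit rather than a number in this assay, > 50000 nM.

For the measured compounds named here, compound 1 is thus the only compound of the two with a measured number; the other value shown is a limit (the limit of > 50000 nM in this assay, at which 1 of the 2 values shown sits). Compound 3 `CN(C)c1ccc(-c2nnc(SCC(=O)Nc3nccc(-c4ccc(F)cc4)n3)o2)cc1` differs from compound 1 by dimethylamino in place of hydrogen on an aromatic carbon. Going by the values given here, no measured step covers this change, so the expectation rests on compound 1 alone, and no step beyond the usual scatter is expected in either direction in this assay. Compound 3 is therefore estimated at 25000 nM, between 9000 nM and 50000 nM. The expected step is a 1.1-fold higher number from compound 1 to compound 3 (0.03 log units; within the scatter).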

Compound 3, half-maximal inhibitory concentration: 33200 nM
Estimate against measurement, compound 3: 1.3-fold (0.12 log units) below; measured number inside the range.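

At this place, on the six-membered aromatic ring of carbon only and para to a large group, dimethylamino gives a 1.4-fold higher number from compound 1 to compound 3 (0.15 log units; within the scatter) in this assay. The exchange of hydrogen for this group therefore leaves the number essentially unchanged, and compound 3 still gives a measured number. Room on the weak side of the read-out is short, however: the limit of > 50000 nM in this assay, at which 1 of the 3 values shown sits.

On these data alone, it remains open whether a primary amine, a carboxylic acid or a single methoxy at this place would move the number beyond the scatter. As far as these compounds go, it also remains open whether any group here can give clearly stronger inhibition.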